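Chloro substitution in the anilide and benzylamide series

The compounds below may be only part of what the source reports. "The series", "measured", "known", "first", "only" and "open" are said of these compounds alone.

Compound 1 `O=C(CCSc1nnc(-c2ccncc2)s1)Nc1ccccc1` and compound 2 `O=C(CCSc1nnc(-c2ccncc2)s1)Nc1ccccc1Cl` sit beside compound 3 `O=C(CCSc1nnc(-c2ccncc2)s1)NCc1ccccc1`; the difference between the cores of compound 1 and compound 3 is benzyl in place of phenyl on an amide-type nitrogen. In an ADME assay on BHK-21 cells (Mesocricetus auratus) for cytotoxicity, with a stated time of 3 days (a higher number here means that more compound is tolerated, a lower number that less compound is tolerated), compound 1 gives > 50000 nM, a limit of the assay rather than a number. Compound 2 likewise gives > 50000 nM, again a limit. Compound 3 gives 18700 nM in this assay, hence an at least 2.6-fold lower number from compound 1 to compound 3 (0.42 log units; beyond the scatter) and an at least 2.6-fold lower number from compound 2 to compound 3 (0.42 log units; beyond the scatter). The change from compound 1 to compound 2 is chloro in place of hydrogen on an aromatic carbon; the step that the two limits leave unreadable from compound 1 to compound 2 cannot be sized because of the limit of > 50000 nM in this assay, at which 2 of the 3 values shown sit. Compound 4 `O=C(CCSc1nnc(-c2ccncc2)s1)NCc1ccc(Cl)cc1` carries the same kind of change on compound 3, (chloro in place of hydrogen on an aromatic carbon), though the place differs: ortho to a large group in compound 2 against para to a large group in compound 4. With the earlier step unreadable, the expected step is a 1.2-fold lower number from compound 3 to compound 4 (0.10 log units; within the scatter), kept small. Compound 4 is estimated at 15000 nM, between 6000 nM and 50000 nM.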

Compound 4, half-maximal cytotoxic concentration: 21500 nM
Compound 4: the middle estimate sits 1.4-fold (0.16 log units) below what was measured; the measured number falls inside the stated range.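

In this assay, chloro in place of hydrogen on the benzyl group gives a 1.1-fold higher number from compound 3 to compound 4 (0.06 log units; within the scatter), so on the core of compound 3 the change shows no readable effect. This does not show that the change is equally silent on the anilide core, and the corresponding step there and the other steps between two limits cannot be read because both values are limits of the assay: the limit of > 50000 nM in this assay, at which 2 of the 4 values shown sit. With chloro present on the benzyl group, the lower number relative to the anilides remains, with an at least 2.3-fold lower number from compound 2 to compound 4 (0.36 log units; beyond the scatter) and an at least 2.3-fold lower number from compound 1 to compound 4 (0.36 log units; beyond the scatter).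

Going by these compounds, it remains open how an amine or a carboxylic acid in place of chloro would read in this assay. On these data alone, a longer chain on the amide nitrogen is equally open.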